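Trifluorophenyl isomers on the shared core, expectation for compound 4

This account rests on a few compounds, and the source may have more. Where it says the series, first, only, none or still open, it means among the compounds named here.

Among the compounds with values here, compound 3 `COc1ccc2[nH]c3c(c2c1)CCNC31CCN(Cc2ccc(F)c(F)c2F)CC1` gives 4100 nM in an assay on FRT cells for positive allosteric modulation of Cystic fibrosis transmembrane conductance regulator variant N1303K (Homo sapiens), in the presence of a further agent that is not named here (on this read-out lower numbers stand for an effect already at smaller amounts and higher numbers for an effect only at larger amounts of compound), the highest of the three numbers measured so far. Compound 1 `COc1ccc2[nH]c3c(c2c1)CCNC31CCN(Cc2cc(F)cc(Cl)c2)CC1` gives 2500 nM in this assay, and compound 2 `COc1ccc2[nH]c3c(c2c1)CCNC31CCN(Cc2ccc(Br)cc2F)CC1` gives 1600 nM. Within the data shown here, the step of a 1.6-fold higher number from compound 1 to compound 3 (0.21 log units; within the scatter) lies within the scatter, whereas a 2.6-fold higher number from compound 2 to compound 3 (0.41 log units; beyond the scatter) is the one step here beyond it; a 1.6-fold lower number from compound 1 to compound 2 (0.19 log units; within the scatter) is again within the scatter. Every measured step alters both the kind and the placement of halogens on the group attached to a saturated chain carbon bound to an amine nitrogen in a ring.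

Compound 4 `COc1ccc2[nH]c3c(c2c1)CCNC31CCN(Cc2cc(F)c(F)cc2F)CC1` changes only the placement: 2,4,5-trifluorophenyl in place of 2,3,4-trifluorophenyl on a saturated chain carbon bound to an amine nitrogen in a ring. Among the measured compounds shown here, no measured step compares two trifluorophenyl isomers, so none bears directly on it; the measured steps, all small, suggest that rearranging halogens on this group moves this assay little. Compound 4 is therefore expected to sit near compound 3, with a 1.2-fold lower number from compound 3 to compound 4 (0.07 log units; within the scatter) as the expected step. The estimate for compound 4 in this assay is 3500 nM, expected to fall between 1500 nM and 8000 nM.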

Compound 4, half-maximal effective concentration: 600 nM
Compound 4: the middle estimate sits 5.8-fold (0.77 log units) above what was measured; measured number below the stated range.
By their numbers in this assay, from the lowest: compound 4; then compounds 2, 1 and 3 (each within the scatter of the next, the first and the last beyond it).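

Placement alone carries weight at this position: the 2,3,4-trifluorophenyl and 2,4,5-trifluorophenyl groups hold the same atoms, yet in this assay the change gives a 6.8-fold lower number from compound 3 to compound 4 (0.83 log units; beyond the scatter) and so undoes the earlier impression that rearranging halogens here moves little. The 2,4,5-trifluorophenyl group also separates from the two mixed-halogen groups, with a 2.7-fold lower number from compound 2 to compound 4 (0.43 log units; beyond the scatter) and a 4.2-fold lower number from compound 1 to compound 4 (0.62 log units; beyond the scatter) as its steps, which puts compound 4 lowest of the four compounds. Nothing available accounts for the gap between the two isomers.

Open, on these data alone, is whether the lower number survives when one fluorine of the 2,4,5-trifluorophenyl group gives way to chlorine, bromine or a nitrile. Also open, as far as these compounds go, is whether a longer chain, such as 2,4,5-trifluorophenethyl, can stand in for the 2,4,5-trifluorobenzyl group.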